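Removing a phenolic hydroxy in two settings of one scaffold

The compounds below may be only part of what the source reports. "The series", "measured", "known", "first", "only" and "open" are said of these compounds alone.

Three compounds of a shared diarylheptanoid-like series were tested in a functional assay on RAW264.7 cells (Mus musculus) for inhibition, read by MTT assay; on this read-out lower numbers stand for stronger inhibition and higher numbers for weaker inhibition. Compound 1 `Oc1ccc(/C=C/CC[C@H](O)CCc2ccc(O)cc2)cc1` gives 9830 nM in this assay. Compound 2 `Oc1ccc(/C=C/CC[C@H](O)CCc2ccc(O)c(O)c2)cc1` carries one more hydroxy and gives 42000 nM in this assay. Compound 3 `O=C(CC/C=C/c1ccc(O)cc1)CCc1ccc(O)cc1` gives 8930 nM in this assay; its number and that of compound 1 lie within the scatter of each other, while its number and that of compound 2 lie clearly apart.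

The measured step of a 4.3-fold lower number from compound 2 to compound 1 (0.63 log units; beyond the scatter) describes the change (hydrogen in place of hydroxy on an aromatic carbon). The difference between the core of compound 2 and the core of compound 3 is not broken down here.

Compound 4 `O=C(CC/C=C/c1ccccc1)CCc1ccc(O)cc1` has not yet been measured. It arises from compound 3 through (hydrogen in place of hydroxy on an aromatic carbon). This is the same kind of change as that from compound 2 to compound 1, but the surroundings differ: in the earlier case the hydroxy left a carbon ortho to a hydroxy group and meta to a large group, whereas here it leaves a carbon para to a large group. The earlier step therefore gives only a loose guide. For the measured compounds named here, for compound 4 an estimated step of a 1.3-fold higher number from compound 3 to compound 4 (0.13 log units; within the scatter) in this assay is expected, resting on the single measured precedent and the fact that the position is not the same. Compound 4 is thus estimated at 12000 nM, with a range from 5000 nM to 30000 nM.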

Compound 4, half-maximal inhibitory concentration: 6980 nM
Compound 4: the middle estimate sits 1.7-fold (0.24 log units) above what was measured; low and high end bracket the measured number.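

In this assay, replacing the hydroxy with hydrogen on the second core gives a 1.3-fold lower number from compound 3 to compound 4 (0.11 log units; within the scatter), so on this core the change from 4-hydroxyphenyl to phenyl has no effect that can be told from the scatter of repeated measurements. The size of the step therefore does not carry over from one core to the other in this small series, and the earlier, clearer step cannot be taken as a general rule for removing a phenolic hydroxy here: the same change on two cores in this assay, a 4.3-fold lower number (0.63 log units; beyond the scatter) from compound 2 to compound 1 and a 1.3-fold lower number (0.11 log units; within the scatter) from compound 3 to compound 4, 3.3-fold (0.52 log units) apart, beyond the scatter of two such steps. What this does not show is why the two steps differ, since each rests on a single pair of compounds, and the hydroxy leaves a different position in each case, so an influence of the core cannot be separated from an influence of that position.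

The compounds shown leave open whether the same step would stay small at other positions on the second core, including removal of the hydroxy on the other aromatic ring of compound 4. They also leave open how a methoxy group or a fluorine in place of that hydroxy, or an amine in place of the carbonyl in the chain, would read in this assay.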